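The source may hold more compounds than are shown below. What is called first, only, known or untested is meant among the compounds shown, and "the series" means these compounds.

Compound 1 `CC(Sc1nnc(-c2ccncc2)s1)C(=O)Nc1ccccc1Cl` – in an ADME assay on HepG2 cells (Homo sapiens) for cytotoxicity, with a stated time of 3 days (on this read-out lower numbers stand for higher toxicity in this test and higher numbers for lower toxicity in this test), compound 1 gives > 50000 nM, which is a limit of the assay.
Compound 2 `CC(Sc1nnc(-c2ccncc2)s1)C(=O)NCc1ccccc1Cl` – in this assay compound 2 gives > 50000 nM, again a limit of the assay.
Compound 3 `O=C(CCSc1nnc(-c2ccncc2)s1)NCc1ccccc1Cl` – in this assay compound 3 gives > 50000 nM, also a limit of the assay.

The three measured compounds share a core and differ in the amide part. Compound 2 and compound 3 are built from the same atoms joined differently; the difference between their two cores is not broken down here. Compound 1 arises from compound 2 by the change (2-chlorophenyl in place of 2-chlorobenzyl on an amide-type nitrogen); the corresponding step is a step that the two limits leave unreadable from compound 2 to compound 1, since both values sit at the same limit. Among the measured compounds shown here, that all three measured values stand at the limit of > 50000 nM in this assay, at which 3 of the 3 values shown sit, is the only evidence available on this change.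

Compound 4 `O=C(CCSc1nnc(-c2ccncc2)s1)Nc1ccccc1Cl` remains to be measured in this assay. It arises from compound 3 by the change (2-chlorophenyl in place of 2-chlorobenzyl on an amide-type nitrogen), the same kind of change as that from compound 2 to compound 1, made at the same place, an amide-type nitrogen whose other neighbour is a carbonyl carbon. Given that compound 3 gives > 50000 nM and that the earlier step is a step that the two limits leave unreadable from compound 2 to compound 1, compound 4 is expected to show a step of a number no higher from compound 3 to compound 4 (the limit leaves the size open), most likely ending at the same limit. The estimate for compound 4 is therefore 50000 nM, between 20000 nM and 100000 nM.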

Compound 4, half-maximal cytotoxic concentration: > 50000 nM
Compound 4: no number, only a limit (the forecaster's own chance of this, stated with the estimate: 85%); the middle value lies on the limit itself.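

In this assay, compound 3 and compound 4 each give a limit of the assay and not a number, so no step can be read between them: the limit of > 50000 nM in this assay, at which 4 of the 4 values shown sit.

The compounds shown leave open what the half-maximal cytotoxic concentration of each compound actually is, and whether 2-chlorophenyl in place of 2-chlorobenzyl on an amide-type nitrogen changes it at all.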